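A few compounds are considered here, and "the series" means these few. Any claim that something is new, unique, unknown or untested is made for them only; others in the source may bear on it.

Measured so far:
- compound 1, `COc1ccc(-c2nc(C)c(C(=O)CSc3nc(-c4cccc(OC)c4)c(C#N)c(=O)[nH]3)s2)cc1`: 43.2% in a functional assay on U-87MG ATCC cells for antiproliferative activity against U-87 MG (Homo sapiens), read by MTT assay, with a stated time of 48 h, tested at 50 uM; a lower number here means a stronger effect, a higher number a weaker effect of the compound at the concentration tested
- compound 2, `COc1ccc(-c2nc(C)c(C(=O)CSc3nc(-c4ccc(Cl)c(Cl)c4)c(C#N)c(=O)[nH]3)s2)cc1`: 78.4% in this assay

Within the data shown here, compound 2 stands highest of these two numbers, which here means the weaker effect; its nearest neighbour is compound 1, and the only measured step, a number 35.2 percentage points higher from compound 1 to compound 2 (beyond the scatter), is large and lies beyond the scatter. Compound 3, `COc1ccc(-c2nc(C)c(C(=O)CSc3nc(-c4ccccc4)c(C#N)c(=O)[nH]3)s2)cc1`, is reached from compound 2 by phenyl in place of 3,4-dichlorophenyl on an aromatic carbon. Among the measured compounds shown here, no measured step swaps the 3,4-dichlorophenyl for a plain phenyl, so the one step known bears on this change only loosely: it shows that what sits on this aromatic carbon can move the number a great deal. A phenyl is neither of the two groups measured, so the expectation is that compound 3 lands between them, with a step of a number 16.4 percentage points lower from compound 2 to compound 3 (beyond the scatter) expected downward, though the uncertainty is wide. The estimate for compound 3 is 62%, ranging from 38% to 86%.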

Compound 3, a percentage reported as activity, at one concentration (the size of the read-out at that concentration, not a potency): 72.5%
Estimate against measurement, compound 3: 10.5 percentage points below, within the range that was stated.
By their numbers in this assay, from the lowest: compound 1; then compounds 3 and 2 (each within the scatter of the next).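

Plain phenyl and 3,4-dichlorophenyl cannot be told apart at this position in this assay, where the step is a number 5.9 percentage points lower from compound 2 to compound 3 (within the scatter). Hydrogen in place of methoxy on that aryl ring, by contrast, gives a number 29.3 percentage points higher from compound 1 to compound 3 (beyond the scatter), so compound 1, with its 3-methoxyphenyl, shows the strongest effect of the three, beyond the scatter from both of the others. No supporting measurement is available to explain this difference.

The compounds shown leave open whether the stronger effect is specific to methoxy or would also appear with a hydroxy, an amino or an ethoxy group in its place. They also leave open whether methoxy must sit where it does in 3-methoxyphenyl, which a 4-methoxyphenyl group would test.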